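Working notes: methoxymethyl to difluoromethoxy on the aromatic ring

The compounds below may be only part of what the source reports. "The series", "measured", "known", "first", "only" and "open" are said of these compounds alone.

Compound 1 `COCc1ccccc1C1Cc2nccn2C1` stands in an in vitro ADME assay on microsomes from liver (Homo sapiens) for metabolic stability (a higher number here means faster removal of the compound, a lower number slower removal), at a limit, not a number: < 7 mL.min-1.g-1. Compound 3 `COc1ccc(C2Cc3nccn3C2)cc1` gives a number, 30 mL.min-1.g-1. Compound 2 `COc1cccc(C2CCc3nc[nH]c3C2)c1` has no usable result, its entry reading "not determined" (no result reported).

The next step leads to compound 4 `FC(F)Oc1ccccc1C1Cc2nccn2C1`: difluoromethoxy in place of methoxymethyl on an aromatic carbon. Difluoromethoxy takes the place of methoxymethyl on an aromatic carbon, ortho to a group of 8 heavy atoms. For the measured compounds named here, no measured pair isolates this change, so the expectation is tentative. In this assay the estimated step of an at least 1.1-fold higher number from compound 1 to compound 4 (0.05 log units; that floor lies within the scatter) is small and upward, possibly no larger than the scatter. Compound 4 is expected at 8 mL.min-1.g-1, within an estimated range of 4 mL.min-1.g-1 to 20 mL.min-1.g-1.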

Compound 4, intrinsic clearance in microsomes: 22 mL.min-1.g-1
For compound 4 the middle estimate is 2.8-fold (0.44 log units) below the measured one; measured number outside the range, above it.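

In this assay, difluoromethoxy in place of methoxymethyl on an aromatic carbon, ortho to a group of 8 heavy atoms, gives an at least 3.1-fold higher number from compound 1 to compound 4 (0.49 log units; beyond the scatter) on the shared core. For the compounds shown here, this position is therefore not indifferent to the group it carries, which the earlier compounds could not show. Only a lower bound on the step can be read, because compound 1 stands at a limit and not at a number: the limit of < 7 mL.min-1.g-1 in this assay, at which 1 of the 4 values shown sits.

The compounds shown leave open how an amine or a carboxylic acid at this position would read in this assay. On these data alone, what in the change drives the step also stays open.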